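The source may hold more compounds than are shown below. What is called first, only, known or untested is meant among the compounds shown, and "the series" means these compounds.

Measured compounds:
compound 1 `CCOC(=O)C1=Cc2ccccc2OC1(OCc1cn(CC(=O)Nc2ccc(C)cc2)nn1)C(F)(F)F`, 67400 nM in a functional assay on HeLa cells (Homo sapiens) for inhibition, read by MTT assay, with a stated time of 24 h; on this read-out higher numbers stand for weaker inhibition and lower numbers for stronger inhibition
compound 2 `O=C(O)C1=Cc2ccccc2OC1(OCc1cc(-c2ccc([N+](=O)[O-])cc2)no1)C(F)(F)F`, > 150000 nM in this assay (a limit)
compound 3 `O=C(O)C1=Cc2ccccc2OC1(OCc1cc(-c2ccc(F)cc2F)no1)C(F)(F)F`, > 150000 nM in this assay (a limit)

For the measured compounds named here, compound 1 is the only member of the series with a numerical value in this assay; compound 2 reports only a limit, > 150000 nM. Compound 3 likewise reports only a limit, > 150000 nM. Both of these sit at the limit of > 150000 nM in this assay, at which 2 of the 3 values shown sit. Going by the values given here, the one step between measured compounds, a step that the two limits leave unreadable from compound 2 to compound 3, is therefore unreadable, and it concerns the ring carried by the core, not the amide nitrogen.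

Compound 4 `CCOC(=O)C1=Cc2ccccc2OC1(OCc1cn(CC(=O)Nc2ccccc2F)nn1)C(F)(F)F` is not yet measured. It differs from compound 1 by 2-fluorophenyl in place of 4-methylphenyl on an amide-type nitrogen. Among the compounds with values here, no measured step touches this position, so nothing speaks for a gain or loss beyond the scatter; the ester of compound 1 is retained, so compound 4 is expected to stay near compound 1 rather than move to the limit seen for compound 2 and compound 3.

Compound 4 is estimated at 70000 nM in this assay, with an expected range from 30000 nM to 150000 nM. The expected step of a 1.0-fold higher number from compound 1 to compound 4 (0.02 log units; within the scatter) is therefore within the scatter.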

Compound 4, half-maximal inhibitory concentration: 49900 nM
Estimate against measurement, compound 4: 1.4-fold (0.15 log units) above; the range from low to high includes it.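

In this assay, for the compounds shown here, replacing 4-methylphenyl with 2-fluorophenyl on the amide-type nitrogen gives a 1.4-fold lower number from compound 1 to compound 4 (0.13 log units; within the scatter), the first readable step at this position, and it shows that this exchange leaves the read-out within the scatter while the ethyl ester and the shared core stay the same. Both the substituent and its ring position change in this one step, so neither can be read alone. No measured property in the series bears on the reason for this outcome.

The step between compound 2 and compound 3 cannot be read because both values are limits, and neither compound differs from compound 1 or compound 4 in one place only, so the carboxylic acid and the ring attached through the core remain unconnected to this amide series. Also open, going by these compounds, is how the read-out would respond to 4-fluorophenyl or 2-methylphenyl on the amide-type nitrogen, which would separate substituent from ring position, or to an aminophenyl group or a longer chain there.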